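The compounds below may be only part of what the source reports. "The series", "measured", "known", "first", "only" and "open" are said of these compounds alone.

The three measured compounds share one core and differ only at one aromatic carbon and in a chain carbon bound to an aromatic nitrogen. Compound 1 `CC(O)Cn1nnnc1-c1ccccc1-c1ccc(CN2C(=O)[C@H](NC(=O)CC(C)(C)N)CCc3ccccc32)cc1` gives 0.05 uM in a functional assay (Pituitary gland cell) with Rattus norvegicus as the target; a lower number here means that less compound is needed, a higher number that more compound is needed for the effect. Compound 2 `CC(C)(N)CC(=O)N[C@@H]1CCc2ccccc2N(Cc2ccc(-c3ccccc3C(=O)O)cc2)C1=O` gives 3 uM in this assay. Compound 3 `Cn1nnnc1-c1ccccc1-c1ccc(CN2C(=O)[C@H](NC(=O)CC(C)(C)N)CCc3ccccc32)cc1` gives 0.5 uM in this assay, which is the second highest of the three numbers. The step of a 6.0-fold lower number from compound 2 to compound 3 (0.78 log units; beyond the scatter) shows what the tetrazole brings in place of the carboxy group, and the step of a 10-fold higher number from compound 1 to compound 3 (1.00 log units; beyond the scatter) shows what is lost when the 1-hydroxyethyl piece is removed from the chain carbon.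

Compound 4 `CC(C)(N)CC(=O)N[C@@H]1CCc2ccccc2N(Cc2ccc(-c3ccccc3S(=O)(=O)NC(C)(C)C)cc2)C1=O` has not yet been measured. Its change from compound 3 is (tert-butyl)sulfamoyl in place of 1-methyl-1H-tetrazol-5-yl on an aromatic carbon. Among the measured compounds shown here, no measured step covers this exact exchange. The step that comes closest is a 6.0-fold lower number from compound 2 to compound 3 (0.78 log units; beyond the scatter), which says that swapping the group at this aromatic carbon moves the number by a modest amount, and the step of a 60-fold higher number from compound 1 to compound 2 (1.78 log units; beyond the scatter) shows that the same position can carry a large difference. For the measured compounds named here, a sulfamoyl group appears in none of the measured compounds, so the direction is uncertain. Compound 4 is therefore estimated at 0.8 uM, with a range from 0.15 uM to 4 uM, an expected step of a 1.6-fold higher number from compound 3 to compound 4 (0.20 log units; within the scatter).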

Compound 4, concentration for half-maximal effect: 4 uM
Estimate against measurement, compound 4: 5.0-fold (0.70 log units) below, within the range that was stated.
By their numbers in this assay, from the lowest: compound 1; then compound 3; then compounds 2 and 4 (each within the scatter of the next).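

At this aromatic carbon, ortho to a large group, replacing the tetrazole of compound 3 with (tert-butyl)sulfamoyl costs much of what that tetrazole gave, with an 8.0-fold higher number from compound 3 to compound 4 (0.90 log units; beyond the scatter) in this assay. The new group also stands level with the carboxy group, as shown by a 1.3-fold higher number from compound 2 to compound 4 (0.12 log units; within the scatter), so the lower numbers at this position in the series so far belong only to the two tetrazole compounds, and the widest gap now reaches an 80-fold higher number from compound 1 to compound 4 (1.90 log units; beyond the scatter). Nothing measured here explains why the tetrazoles give lower numbers than these two other groups.

The compounds shown leave open whether the tert-butyl part or the sulfamoyl part accounts for the higher number, which a plain sulfamoyl group with two hydrogens on its nitrogen, or one carrying a single methyl, could help to separate. They also leave open how far the gain from the 1-(2-hydroxypropyl) chain on the tetrazole extends, for example to a longer chain ending in a hydroxyl group or to a chain ending in an amine.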